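The compounds below may be only part of what the source reports. "The series", "measured", "known", "first", "only" and "open" are said of these compounds alone.

Values in a functional assay on SK-MEL-28 cells (Homo sapiens) for inhibition, read by colorimetric assay and MTT assay, with a stated time of 72 h; on this read-out lower numbers stand for stronger inhibition and higher numbers for weaker inhibition:

compound 1 `COc1cc(C(=O)NNC(=S)Nc2csc(-c3ccccc3)c2)cc(OC)c1OC`: 55000 nM
compound 2 `COc1ccc(C(=O)NNC(=S)Nc2csc(-c3ccccc3)c2)cc1`: 30000 nM
compound 3 `O=C(NNC(=S)Nc1csc(-c2ccccc2)c1)c1ccc(O)cc1`: 71000 nM

Compound 2 gives the lowest of the three numbers, although compound 1 lies within the scatter of it; only compound 3 lies beyond, through the step of a 2.4-fold higher number from compound 2 to compound 3 (0.37 log units; beyond the scatter), hydrogen in place of methyl on the oxygen. Compound 4 `COc1ccc(C(=O)NNC(=S)Nc2csc(-c3ccccc3)c2)cc1OC` differs from compound 2 by methoxy in place of hydrogen on an aromatic carbon. Going by the values given here, no measured step adds a methoxy group, so the demethylation step does not bear directly on this change; the nearest guide is compound 1, which carries further methoxy groups and in this assay gives 55000 nM, within the scatter of compound 2. A step of a 1.3-fold higher number from compound 2 to compound 4 (0.12 log units; within the scatter) is therefore expected, nothing beyond the scatter. Compound 4 is estimated at 40000 nM, with a range from 20000 nM to 80000 nM.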

Compound 4, half-maximal inhibitory concentration: 28000 nM
Estimate against measurement, compound 4: 1.4-fold (0.15 log units) above, within the range that was stated.
By their numbers in this assay, from the lowest: compounds 4, 2, 1 and 3 (each within the scatter of the next, the first and the last beyond it).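

Methoxy in place of hydrogen on this aromatic carbon, ortho to a methoxy group, leaves the number within the scatter (a 1.1-fold lower number from compound 2 to compound 4 (0.03 log units; within the scatter)). The step hydrogen in place of methoxy (a 2.0-fold lower number from compound 1 to compound 4 (0.29 log units; within the scatter)) also stays within the scatter, so compound 1, compound 2 and compound 4 cannot be told apart, and this position shows no readable response to methoxy. No measurement on hand accounts for this.

Still open, going by these compounds, is whether any other group at this carbon, such as an amine or a carboxylic acid, would move the number beyond the scatter. On these data alone, a longer chain on the oxygen is equally open.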